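Removing cyclohexylmethoxy from compound 1

The source may report more compounds than this note shows. Statements on the series, on what has been measured and on what is new or still open speak of the compounds shown alone.

In a functional assay on PC-3 cells (Homo sapiens) for antiproliferative activity, read by XTT assay (on this read-out lower numbers stand for stronger inhibition and higher numbers for weaker inhibition), compound 1 (`O=c1c(Cc2coc3cccc(OCC4CCCCC4)c3c2=O)coc2ccccc12`) gives 4510 nM and lies within the scatter of compound 3 (`Cc1ccc2c(=O)c(Cc3coc4cccc(OCC5CCCCC5)c4c3=O)coc2c1`), which gives 2440 nM here. Compound 2 (`O=c1c(Cc2coc3cccc(OCC4CCCCC4)c3c2=O)coc2cc(Cl)ccc12`) reaches only a limit (> 10000 nM). Compound 4 (`O=c1c(Cc2coc3ccccc3c2=O)coc2ccccc12`) carries hydrogen in place of cyclohexylmethoxy on an aromatic carbon. Within the data shown here, no measured step changes this group, so the others bear on it only indirectly. Chloro in place of hydrogen gave an at least 2.2-fold higher number from compound 1 to compound 2 (0.34 log units; beyond the scatter) and methyl in place of hydrogen gave a 1.8-fold lower number from compound 1 to compound 3 (0.27 log units; within the scatter) as a smaller change. The group that leaves is much larger than either, so weaker inhibition is expected. The expected change is a 2.0-fold higher number from compound 1 to compound 4 (0.30 log units; within the scatter) and its size is only an estimate. Compound 4 is expected at 9000 nM with an estimated range from 3000 nM to 30000 nM in this read-out.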

Compound 4, half-maximal inhibitory concentration: 7400 nM
The estimate for compound 4 lay 1.2-fold (0.09 log units) above the measured number; measured number inside the range.
By their numbers in this assay, from the lowest: compounds 3, 1 and 4 (each within the scatter of the next, the first and the last beyond it). At a limit, above all of these: compound 2.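

In this assay, the whole cyclohexylmethoxy group gives way to hydrogen with the step staying within the scatter (a 1.6-fold higher number from compound 1 to compound 4 (0.22 log units; within the scatter)). Among these compounds, this is the first direct comparison at this position, and it shows that the cyclohexylmethoxy group is not required for the activity of compound 1 on this read-out. The loss of its ring and its oxygen produces no difference that can be told from repeat measurements.

As far as these compounds go, how a methoxy group or an amine at this position would read remains open. What lies behind this step, the data shown do not tell.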